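The compounds below may be only part of what the source reports. "The series", "measured", "known", "first", "only" and "open" are said of these compounds alone.

Measured so far in a functional assay on SK-OV-3 cells (Homo sapiens) for cytotoxicity, read by MTT assay, with a stated time of 48 h; a higher number here means a weaker inhibitor, a lower number a stronger inhibitor:
- compound 1, `O=C(/C=C/c1ccc2c(c1)B(O)OC2)c1ccc(-c2ccccc2)cc1`, gives 4900 nM
- compound 2, `O=C(/C=C/c1ccc2c(c1)B(O)OC2)c1ccc(F)cc1`, gives 1400 nM

Compound 2 stands at the lower of the two numbers, and its nearest neighbour is compound 1, separated by a 3.5-fold lower number from compound 1 to compound 2 (0.54 log units; beyond the scatter). Among the compounds with values here, that step swaps a phenyl for a fluoro on an aromatic carbon of the aryl ketone, and it is the only measured step so far.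

Compound 3, `O=C(/C=C/c1ccc2c(c1)B(O)OC2)c1ccc(Br)cc1`, differs from compound 2 at that same carbon: bromo in place of fluoro on an aromatic carbon. Within the data shown here, no measured pair shows a bromo against a fluoro, so the one step on hand, from a phenyl to a fluoro, is only an indirect guide: it shows that the group on this aromatic carbon can move the number beyond the scatter, with the smaller group giving the lower value. A bromo is a single-atom group like the fluoro, so no large step is expected in this assay, with at most a drift toward a somewhat higher number. The expected step is a 1.4-fold higher number from compound 2 to compound 3 (0.13 log units; within the scatter), and compound 3 is expected to give about 1900 nM, within a range of 700 nM to 5000 nM.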

Compound 3, half-maximal inhibitory concentration: 4500 nM
Estimate against measurement, compound 3: 2.4-fold (0.37 log units) below; measured number inside the range.
By their numbers in this assay, from the lowest: compound 2; then compounds 3 and 1 (each within the scatter of the next).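

In this assay the exchange of one single-atom group for another at this aromatic carbon is enough to shift the result, with a 3.2-fold higher number from compound 2 to compound 3 (0.51 log units; beyond the scatter) here, so an equal heavy-atom count does not guarantee an equal number. The bromo also matches the much larger-looking phenyl, with a 1.1-fold lower number from compound 1 to compound 3 (0.04 log units; within the scatter) between them, which means that among these three compounds the low number belongs to compound 2 alone and does not simply follow the size of the group. Nothing available explains why the fluoro and bromo compounds part in this way.

From the compounds shown here alone, whether fluoro is special here or bromo and phenyl simply share a common level stays open, and a chloro, which would sit among the single-atom halogens, or a plain hydrogen at this carbon would help to separate those two readings. A methoxy group or an amine at the same place would further show whether anything other than a halogen can reach the number of compound 2.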